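A few compounds are considered here, and "the series" means these few. Any claim that something is new, unique, unknown or untested is made for them only; others in the source may bear on it.

Compound 3 `c1ccc(-n2cc3cnc(-c4ccsc4)cc3n2)cc1` and compound 1 `Cc1nc(-c2ccsc2)cc2nn(-c3ccccc3)cc12` share one core; compound 1 carries a methyl in place of hydrogen on an aromatic carbon. In a functional assay on MCF7 cells (Homo sapiens) for inhibition, read by fluorescence, with a stated time of 72 h (on this read-out lower numbers stand for stronger inhibition of growth and higher numbers for weaker inhibition of growth), compound 3 gives 9800 nM, while compound 1 gives 22200 nM, a step of a 2.3-fold higher number from compound 3 to compound 1 (0.36 log units; beyond the scatter). Compound 2 `c1ccc(-n2cc3cnccc3n2)cc1` differs from compound 3 by hydrogen in place of thiophen-3-yl on an aromatic carbon. In this assay compound 2 reaches only a limit, > 100000 nM. The step of an at least 10-fold lower number from compound 2 to compound 3 (1.00 log units; beyond the scatter) therefore rests on (the limit of > 100000 nM in this assay, at which 1 of the 3 values shown sits), a limit rather than a number. Compound 4 `Cc1nccc2nn(-c3ccccc3)cc12` stands to compound 2 as compound 1 stands to compound 3: methyl in place of hydrogen on an aromatic carbon. The surroundings are not identical, since in compound 3 the carbon is also meta to a thiophen-3-yl group, which compound 2 lacks, so this is the same kind of change, not the same one. Starting from the limit of compound 2, the expected step is a step that the limit leaves unreadable from compound 2 to compound 4, so compound 4 is expected to give about 200000 nM, most likely again only a limit.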

Compound 4, concentration for 50% growth inhibition: > 100000 nM
Compound 4 gave a limit, no number; the forecaster's own chance of this, stated with the estimate: 80%; the middle value is on the limit's open side.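

In this assay compound 4 reaches only a limit, > 100000 nM. The steps between compound 2 and compound 4 cannot be read, so methyl in place of hydrogen has a measurable size only on the core carrying thiophen-3-yl, and nothing here shows that this size carries over to the core without it. The other change can be followed on both cores, since hydrogen in place of thiophen-3-yl gives an at least 4.5-fold higher number from compound 1 to compound 4 (0.65 log units; beyond the scatter), which points the same way as on the core without methyl, though agreement in direction is all that can be claimed and the sizes cannot be compared: the same change on two cores in this assay, an at least 10-fold lower number (1.00 log units; beyond the scatter) from compound 2 to compound 3 and an at least 4.5-fold lower number (0.65 log units; beyond the scatter) from compound 4 to compound 1; the limit leaves it open whether they differ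

With only thiophen-3-yl and hydrogen at that aromatic carbon, the compounds shown leave open whether a different group there, such as an amine or a carboxylic acid, would lower the number further. They also leave open whether a longer chain, such as ethyl, would behave as methyl does on the core of compound 1.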